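The source may hold more compounds than are shown below. What is called first, only, known or untested is meant among the compounds shown, and "the series" means these compounds.

Of the compounds shown here, three of related build have been measured in a functional assay on BV-2 cells (Mus musculus), with stated times of 2 h and 24 h, tested at 1 uM; a lower number here means a stronger effect, a higher number a weaker effect of the compound at the concentration tested. Compound 1 `O=C(CCc1ccc(O)cc1)C[C@@H]1O[C@@H](c2ccc(O)cc2)[C@H]2[C@@H]1[C@H](c1ccc(O)cc1)O[C@H]2CC(=O)CCc1ccc(O)cc1` gives 101% in this assay. Compound 2 `COc1cc(/C=C/C=C/C(=O)CCc2ccc(O)cc2)cc(OC)c1O` gives 96.8% in this assay. Compound 3 `Oc1ccc(CC[C@@H](O)C[C@H](O)CCc2ccc(O)cc2)cc1` gives 102% in this assay. Compound 3 stands at the highest of the three numbers, but its gap to compound 1 and its gap to compound 2 both lie within the usual scatter of repeated measurements, so the three results cannot be told apart, and none of them shows a notable effect at the concentration tested.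

Compound 4 `COc1cc(CC[C@@H](O)C[C@H](O)CCc2ccc(O)cc2)ccc1O` has not yet been measured in this assay. It differs from compound 3 in one place: methoxy in place of hydrogen on an aromatic carbon. The rest of the molecule is unchanged.

Going by the values given here, no step between measured compounds is available to show what such a change does. Among the compounds with values here, the only guide is that compound 3 gives 102% in this assay, and these data give no indication that the added group would move the number. The expected step is a number 2 percentage points lower from compound 3 to compound 4 (within the scatter), which is to say no change beyond the scatter. Compound 4 is estimated to give 100% in this assay, with a range from 88% to 110%.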

Compound 4, a percentage reported as activity, at one concentration (the size of the read-out at that concentration, not a potency): 99.4%
For compound 4 the middle estimate is 0.6 percentage points above the measured one; measured number inside the range.
By their numbers in this assay, from the lowest: compounds 2, 4, 1 and 3 (each within the scatter of the next).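

Going by these compounds alone, until now the series held no step that isolated a single change. Methoxy in place of hydrogen on an aromatic carbon, ortho to a hydroxy group, gives a number 2.6 percentage points lower from compound 3 to compound 4 (within the scatter) in this assay, so adding this group at this position produces no change that can be told from the scatter. Within the data shown here, the step also starts from a compound without a notable effect at the concentration tested, so it shows only that this change does not bring out such an effect here, and no measurement at hand points to anything that would account for the result.

Going by these compounds, it remains open whether a different group at the same position, such as an ethoxy, an amine or a carboxylic acid, would move the number beyond the scatter. The compounds shown also leave open whether the same methoxy would have a readable effect on a compound that already shows a clear effect in this assay, as none of those shown here does.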